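A few compounds are considered here, and "the series" means these few. Any claim that something is new, unique, unknown or untested is made for them only; others in the source may bear on it.

Of the compounds shown here, three built on one shared core have been measured in an ADME assay on Huh-7 cells (Homo sapiens) for cytotoxicity, read by a luciferase reporter and WST assay, with a stated time of 3 days; a higher number here means that more compound is tolerated, a lower number that less compound is tolerated. Compound 1 `O=C(Nc1ccccc1)c1c(NO)cc(-c2ccc(F)cc2)oc1=O` carries a 4-fluorophenyl group, and in this assay compound 1 gives 10300 nM. Compound 2 `O=C(Nc1ccc(F)cc1)c1c(NO)cc(-c2ccccc2)oc1=O` carries its fluoro elsewhere and a plain phenyl group instead; in this assay compound 2 reaches only the limit of the measurement, > 20000 nM. Compound 3 `Cc1ccc(NC(=O)c2c(NO)cc(-c3ccccc3)oc2=O)cc1` has a methyl in place of that fluoro on an aromatic carbon, and in this assay compound 3 likewise reaches only the limit, > 20000 nM. The step that the two limits leave unreadable from compound 2 to compound 3 cannot be read because the limit of > 20000 nM in this assay, at which 2 of the 3 values shown sit, hides its size. Compound 3 therefore stands at the limit, with one other value beside it also a limit. Compound 4 `Cc1ccc(NC(=O)c2c(NO)cc(-c3ccc(F)cc3)oc2=O)cc1` differs from compound 3 by fluoro in place of hydrogen on an aromatic carbon. Among the measured compounds shown here, no measured pair changes exactly this spot in one move. For the measured compounds named here, the only measured compound carrying this 4-fluorophenyl group is compound 1, which gives 10300 nM. Compound 3 itself sits at the limit, so no direction can be read from it. The step of an at least 1.1-fold lower number from compound 3 to compound 4 (0.04 log units; that floor lies within the scatter) is thus expected to be none beyond the scatter. Compound 4 is expected to give 18000 nM in this assay, within a range from 7000 nM to 40000 nM, with a fair chance that only the limit is again reported.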

Compound 4, half-maximal cytotoxic concentration: > 20000 nM
Compound 4: a limit, no number (the forecaster's own chance of this, stated with the estimate: 50%); middle value at least 1.1-fold (0.04 log units) from the limit.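

Among the compounds shown here, until now, compound 1 was the only compound with a number, and it was also the only one carrying the 4-fluorophenyl group. Compound 4 carries that group too, yet it reports only a limit in this assay, so the group on this core does not always give a measurable number. The step of an at least 1.9-fold higher number from compound 1 to compound 4 (0.28 log units; that floor lies within the scatter) is only a floor, which leaves the effect of methyl in place of hydrogen on this aromatic carbon unsettled, and the step for adding the fluoro cannot be read: the limit of > 20000 nM in this assay, at which 3 of the 4 values shown sit.

As far as these compounds go, how far tolerance extends past the limit for compound 2, compound 3 and compound 4 stays open. Also open, from the compounds shown here alone, is whether an amine or a carboxylic acid at the place of the methyl would bring a readable number.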